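This account rests on a few compounds, and the source may have more. Where it says the series, first, only, none or still open, it means among the compounds named here.

Measured in a functional assay on SGC-7901 cells (Homo sapiens) for antiproliferative activity, read by MTT assay, with a stated time of 24 h; a higher number here means a weaker inhibitor, a lower number a stronger inhibitor:
- compound 1 `O=C(NNc1ccccc1F)c1ccccc1NS(=O)(=O)c1cnc(O)nc1O`: > 20000 nM, a limit and not a number
- compound 2 `CCCCOc1ccc(C(=O)NNC(=O)c2ccccc2NS(=O)(=O)c2cnc(O)nc2O)cc1`: 6890 nM
- compound 3 `Cc1ccccc1C(=O)NNC(=O)c1ccccc1NS(=O)(=O)c1cnc(O)nc1O`: 13000 nM

In this assay compound 3 gives 13000 nM and compound 2 gives 6890 nM, two values within the scatter of each other. Compound 1 is known only through its limit.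

Compound 4 `O=C(NNC(=O)c1ccccc1NS(=O)(=O)c1cnc(O)nc1O)c1ccccc1Cl` is still to be measured. It differs from compound 3 by chloro in place of methyl on an aromatic carbon, ortho to a large group, so that 2-methylphenyl becomes 2-chlorophenyl: chloro in place of methyl on an aromatic carbon.

Among the compounds with values here, no measured step makes this exchange. Within the data shown here, two steps touch the same part of the series: a 1.9-fold higher number from compound 2 to compound 3 (0.28 log units; within the scatter), which replaces the whole aryl group on the carbonyl carbon, and an at least 1.5-fold lower number from compound 1 to compound 3 (0.18 log units; that floor lies within the scatter). Neither goes beyond the scatter, although both are larger changes than the one at hand. No step beyond the scatter is therefore expected in this assay, in either direction.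

The estimated step is a 1.1-fold lower number from compound 3 to compound 4 (0.03 log units; within the scatter). A result reported only as a limit remains possible, given (the limit of > 20000 nM in this assay, at which 1 of the 3 values shown sits). For compound 4 the expected value is 12000 nM, with an estimated range from 6000 nM to 20000 nM.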

Compound 4, half-maximal inhibitory concentration: 2410 nM
Compound 4: the middle estimate sits 5.0-fold (0.70 log units) above what was measured; measured number below the stated range.
By their numbers in this assay, from the lowest: compound 4; then compounds 2 and 3 (each within the scatter of the next). At a limit, above all of these: compound 1.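

In this assay, within the data shown here, chloro in place of methyl on an aromatic carbon, ortho to a large group, gives a 5.4-fold lower number from compound 3 to compound 4 (0.73 log units; beyond the scatter) and so shows that this single-atom exchange can move the read-out beyond the scatter, which no earlier step did. The change from 4-butoxyphenyl to 2-methylphenyl on the carbonyl carbon gave only a 1.9-fold higher number from compound 2 to compound 3 (0.28 log units; within the scatter), while the change from 4-butoxyphenyl to 2-chlorophenyl gives a 2.9-fold lower number from compound 2 to compound 4 (0.46 log units; beyond the scatter) and places compound 4 as the strongest of the four compounds in this assay. Compound 1 is held at a limit, so an at least 8.2-fold lower number from compound 1 to compound 4 (0.91 log units; beyond the scatter) can be read only as a floor: the limit of > 20000 nM in this assay, at which 1 of the 4 values shown sits.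

Whether bromo, methoxy or a nitrile at this place would follow chloro or methyl remains open, and so does what lies behind the step itself. Also open, as far as these compounds go, is whether a 2-chlorophenyl group keeps this standing in cell lines other than the one used in this assay.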